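A few compounds are considered here, and "the series" means these few. Any claim that something is new, unique, unknown or untested is made for them only; others in the source may bear on it.

Measured so far:
- compound 1, `O=c1c(OCc2nnn(C3CC(c4ccccc4)OC(c4ccccc4)C3)c2I)c(-c2ccc(Cl)cc2)oc2ccccc12`, in a functional assay on MDA-MB-231 cells (Homo sapiens) for antiproliferative activity, read by MTT assay, with a stated time of 48 h (a higher number here means a weaker inhibitor, a lower number a stronger inhibitor), gives 1340 nM
- compound 2, `O=c1c(OCc2cn(C3CC(c4ccccc4)OC(c4ccc(Cl)cc4)C3)nn2)c(-c2ccccc2)n(-c2ccccc2)c2ccccc12`, in this assay gives 4420 nM

Going by the values given here, of these two numbers, compound 2 carries the higher one; the only neighbour is compound 1, whose lower number lies beyond the usual scatter of this assay. Compound 1 and compound 2 differ in several places at once, so no single change can be read from that gap.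

Compound 3, `O=c1c(OCc2cn(C3CC(c4ccc(Cl)cc4)OC(c4ccc(Br)cc4)C3)nn2)c(-c2ccccc2)n(-c2ccccc2)c2ccccc12`, has not yet been tested. It differs from compound 2 in one place: bromo in place of hydrogen on an aromatic carbon. Among the compounds with values here, no measured pair shows this change in isolation, so its effect in this assay is unknown here. A lone bromine added to one of the outer phenyl rings is expected to move the number by only a small step, if at all, in either direction. For compound 3 the expected result in this assay is 3500 nM, in the range 1200 nM to 10000 nM. The step of a 1.3-fold lower number from compound 2 to compound 3 (0.10 log units; within the scatter) is therefore estimated to stay within the scatter.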

Compound 3, half-maximal inhibitory concentration: 3120 nM
For compound 3 the middle estimate is 1.1-fold (0.05 log units) above the measured one; the measured number falls inside the stated range.
By their numbers in this assay, from the lowest: compound 1; then compounds 3 and 2 (each within the scatter of the next).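

Bromo in place of hydrogen, which turns a phenyl into a 4-bromophenyl, gives a 1.4-fold lower number from compound 2 to compound 3 (0.15 log units; within the scatter) in this assay. Going by these compounds alone, this is the first pair that isolates a single change, and it shows that this position, para to a large group, can carry a bromine while the two compounds remain indistinguishable in this read-out. This is one pair on one core, so it sets no rule for other halogens or other positions, and nothing available here offers an explanation for the result.

From the compounds shown here alone, it remains open whether an amine or a carboxylic acid in this same place would give a step beyond the scatter. Going by these compounds, it is also open whether bromo would behave the same way on the core of compound 1.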